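Bis-benzimidazoles: naphthyl swap carried onto the piperazine core

The compounds below may be only part of what the source reports. "The series", "measured", "known", "first", "only" and "open" are said of these compounds alone.

Measured so far in a functional assay on RPMI 8402 cells (Homo sapiens) for cytotoxicity; a higher number here means a weaker inhibitor, a lower number a stronger inhibitor:
compound 1 `Cc1ccc(-c2nc3cc(-c4nc5cc(C#N)ccc5[nH]4)ccc3[nH]2)cc1` gives 570 nM
compound 2 `N#Cc1ccc2[nH]c(-c3ccc4[nH]c(-c5cccc6ccccc56)nc4c3)nc2c1` gives 650 nM
compound 3 `Cc1ccc(-c2nc3cc(-c4nc5cc(N6CCN(C)CC6)ccc5[nH]4)ccc3[nH]2)cc1` gives 830 nM

The three numbers lie close together. Compound 2 differs from compound 1 by naphthalen-1-yl in place of 4-methylphenyl on an aromatic carbon, which gave a 1.1-fold higher number from compound 1 to compound 2 (0.06 log units; within the scatter). Compound 3 differs from compound 1 by 4-methylpiperazin-1-yl in place of cyano on an aromatic carbon, with a 1.5-fold higher number from compound 1 to compound 3 (0.16 log units; within the scatter). Compound 4 `CN1CCN(c2ccc3[nH]c(-c4ccc5[nH]c(-c6cccc7ccccc67)nc5c4)nc3c2)CC1` is not yet measured; it differs from compound 3 by naphthalen-1-yl in place of 4-methylphenyl on an aromatic carbon, the same change as from compound 1 to compound 2, described at the same place in the same words, but made on the core of compound 3 rather than that of compound 1. For compound 4 a step of about a 1.1-fold higher number from compound 3 to compound 4 (0.04 log units; within the scatter) is expected because the earlier occurrence of this change gave a 1.1-fold higher number from compound 1 to compound 2 (0.06 log units; within the scatter), and this rests on that single precedent together with the narrow spread of the three values. Compound 4 is therefore estimated at 900 nM in this assay, with a likely range from 450 nM to 1800 nM.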

Compound 4, half-maximal inhibitory concentration: 330 nM
The estimate for compound 4 lay 2.7-fold (0.44 log units) above the measured number; the measured number lies below the stated range.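

In this assay, naphthalen-1-yl in place of 4-methylphenyl gave a 2.5-fold lower number from compound 3 to compound 4 (0.40 log units; beyond the scatter) and so did not carry over unchanged from the core of compound 1: the same change on two cores in this assay, a 1.1-fold higher number (0.06 log units; within the scatter) from compound 1 to compound 2 and a 2.5-fold lower number (0.40 log units; beyond the scatter) from compound 3 to compound 4, 2.9-fold (0.46 log units) apart, beyond the scatter of two such steps

The same four compounds also give, for 4-methylpiperazin-1-yl in place of cyano, a 2.0-fold lower number from compound 2 to compound 4 (0.29 log units; within the scatter) and this step too differs from its earlier counterpart: the same change on two cores in this assay, a 1.5-fold higher number (0.16 log units; within the scatter) from compound 1 to compound 3 and a 2.0-fold lower number (0.29 log units; within the scatter) from compound 2 to compound 4, 2.9-fold (0.46 log units) apart, beyond the scatter of two such steps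

Both comparisons rest on this one set of four compounds, so they show that the two changes do not add up here, but not why, nor whether this holds on any other core.

Open, going by these compounds, is whether the effect of naphthalen-1-yl depends on 4-methylpiperazin-1-yl specifically. A morpholine or a primary amine at that place, each paired with 4-methylphenyl and with naphthalen-1-yl, would test this.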